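Swapping Dimethylamino for Methoxy in Quinolinone Amines

The compounds below may be only part of what the source reports. "The series", "measured", "known", "first", "only" and "open" are said of these compounds alone.

Three compounds sharing a related core were tested in a toxicity assay on MDCK cells (Canis lupus familiaris) for cytotoxicity, read by crystal violet staining, with a stated time of 48 h; on this read-out lower numbers stand for higher toxicity in this test and higher numbers for lower toxicity in this test. Compound 1 `COc1ccc(CN(Cc2ccc(C(C)(C)C)cc2)Cc2cc3cc(C)ccc3[nH]c2=O)cc1` reached only a limit: in this assay compound 1 gives > 10000 nM, which is a limit of the assay and not a number. Compound 2 `Cc1ccc2[nH]c(=O)c(CN(Cc3ccc(N(C)C)cc3)Cc3ccc(C(C)(C)C)cc3)cc2c1` likewise stopped at a limit: in this assay compound 2 gives > 5000 nM. The change from compound 2 to compound 1 is methoxy in place of dimethylamino on an aromatic carbon, and its size is a step that the two limits leave unreadable from compound 2 to compound 1, because both the limit of > 5000 nM in this assay, at which 1 of the 3 values shown sits, and the limit of > 10000 nM in this assay, at which 1 of the 3 values shown sits, are limits. Going by the values given here, compound 3 `CC(c1ccc(N(C)C)c(Cl)c1)N(Cc1ccc(C(C)(C)C)cc1)Cc1cc2cc(Br)ccc2[nH]c1=O` is the only one with a real number: in this assay compound 3 gives 6100 nM. How the core of compound 3 differs from the core of compound 2 is not broken down here.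

Compound 4 `COc1ccc(C(C)N(Cc2ccc(C(C)(C)C)cc2)Cc2cc3cc(Br)ccc3[nH]c2=O)cc1Cl` has not been measured. It differs from compound 3 by methoxy in place of dimethylamino on an aromatic carbon, the same kind of change as from compound 2 to compound 1, though here the place is ortho to a chloro group. Since the earlier step could not be read, the expectation rests mainly on compound 3 and its value 6100 nM. The expected step is a 1.3-fold higher number from compound 3 to compound 4 (0.12 log units; within the scatter), and compound 4 is estimated at 8000 nM, between 3000 nM and 20000 nM.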

Compound 4, half-maximal cytotoxic concentration: > 10000 nM
Compound 4 was reported as a limit; the forecaster's own chance of this, stated with the estimate: 40%; at least 1.2-fold (0.09 log units) between middle value and limit.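

In this assay, putting methoxy in place of dimethylamino on the core of compound 3 gives an at least 1.6-fold higher number from compound 3 to compound 4 (0.21 log units; that floor lies within the scatter), so the step can be sized only from its lower end, and that floor lies within the usual scatter of repeated measurements. Going by these compounds alone, the same swap on the core of compound 2 cannot be read, which leaves no second step to set beside this one, so the data neither confirm nor refute that the change carries from one core to the other. All they show is that the two methoxy compounds, compound 1 and compound 4, end at one shared limit: the limit of > 10000 nM in this assay, at which 2 of the 4 values shown sit.

The compounds shown leave open how methylamino, hydroxyl or ethoxy would read at the same place on the ring. Also open, from the compounds shown here alone, is the real size of the step, which only a number for compound 4 in place of its limit could give.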